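This account rests on a few compounds, and the source may have more. Where it says the series, first, only, none or still open, it means among the compounds named here.

Compound 3 `CN1CCC[C@@H]1Cn1nc(CCc2ccccc2)c2ccccc2c1=O` gives 200 nM in an assay for binding affinity to Alpha-1B adrenergic receptor (Homo sapiens) (on this read-out lower numbers stand for stronger inhibition and higher numbers for weaker inhibition), the lowest of the two numbers available here. Compound 1 `CN1CCC[C@@H]1Cn1nc(Cc2cccc(F)c2)c2ccccc2c1=O` gives 398 nM in this assay, and the step of a 2.0-fold lower number from compound 1 to compound 3 (0.30 log units; within the scatter) stays within the scatter. For compound 2 `COc1cccc(Cc2nn(C[C@H]3CCCN3C)c(=O)c3ccccc23)c1` the assay reports only a limit, > 1990 nM, as noted in the limit of > 1990 nM in this assay, at which 1 of the 3 values shown sits. The step of an at least 9.9-fold lower number from compound 2 to compound 3 (0.99 log units; beyond the scatter) lies beyond the scatter.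

Compound 4 `CN1CCC[C@@H]1Cn1nc(Cc2ccc(F)c(F)c2)c2ccccc2c1=O` differs from compound 3 by 3,4-difluorophenyl in place of benzyl on a saturated chain carbon bound to an aromatic carbon. This change runs the step from compound 1 to compound 3 backwards, restoring a fluoro on the aromatic ring and adding a second one, while the step from compound 2 to compound 3 shows that a larger substituent on that ring weakens binding sharply. The step from compound 1 to compound 3 was within the scatter, so for compound 4 only a modest rise in the inhibition constant is expected, about a 2.3-fold higher number from compound 3 to compound 4 (0.35 log units; beyond the scatter). Compound 4 is therefore estimated at 450 nM in this assay, with a range from 180 nM to 1400 nM.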

Compound 4, inhibition constant: 316 nM
Estimate against measurement, compound 4: 1.4-fold (0.15 log units) above; the measured number falls inside the stated range.
By their numbers in this assay, from the lowest: compounds 3, 4 and 1 (each within the scatter of the next). At a limit, above all of these: compound 2.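

In this assay, fluoro in place of hydrogen on an aromatic carbon gives a 1.3-fold lower number from compound 1 to compound 4 (0.10 log units; within the scatter), and 3,4-difluorophenyl in place of benzyl gives a 1.6-fold higher number from compound 3 to compound 4 (0.20 log units; within the scatter), so neither the added fluoro nor the change from phenethyl to 3,4-difluorobenzyl moves the number beyond the scatter. The step of an at least 6.2-fold lower number from compound 2 to compound 4 (0.79 log units; beyond the scatter) shows that the sharp difference seen with compound 2 also holds against a ring carrying two fluoro groups. That comparison has only a lower bound, since compound 2 gives a limit and not a number: the limit of > 1990 nM in this assay, at which 1 of the 4 values shown sits.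

The compounds shown leave open how a chloro, a hydroxyl or a trifluoromethyl on this ring would read. Also open, from the compounds shown here alone, is whether a chain longer than phenethyl would keep the number within the scatter of compound 3.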